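A few compounds are considered here, and "the series" means these few. Any claim that something is new, unique, unknown or untested is made for them only; others in the source may bear on it.

Working notes on the series. In a functional assay with Oryctolagus cuniculus as the target (a higher number here means a weaker inhibitor, a lower number a stronger inhibitor), compound 2 `COc1ccc(-c2nc(/N=C(\N)[N+]3(C)CCCCC3)sc2-c2ccc(OC)cc2)cc1` stands only at a limit, > 1000 nM. Compound 1 `CC/N=C(/N)Nc1nc(-c2ccc(OC)cc2)c(-c2ccc(OC)cc2)s1` is also only a limit, > 100 nM. Compound 3 `COc1ccc(-c2nc(CN(C)C)sc2-c2ccc(OC)cc2)cc1` gives a real number, 96 nM.

Compound 4 `COc1ccc(-c2nc(CNC(=O)c3cccnc3)sc2-c2ccc(OC)cc2)cc1` changes one group of compound 2: a group of 10 heavy atoms (7 carbon, 2 nitrogen, 1 oxygen; one six-membered aromatic ring with 1 hetero atom) in place of a group of 10 heavy atoms (7 carbon, 3 nitrogen; one six-membered non-aromatic ring with 1 hetero atom), on an aromatic carbon. The group with net charge +1 leaves, and (((pyridin-3-yl)carbonyl)amino)methyl, with no net charge, enters.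

The readable guide is an at least 10-fold lower number from compound 2 to compound 3 (1.01 log units; beyond the scatter), a large step on the same aromatic carbon. By contrast, an at least 1.0-fold lower number from compound 1 to compound 3 (0.01 log units; that floor lies within the scatter) stays within the scatter at its floor, and a step that the two limits leave unreadable from compound 1 to compound 2 says nothing on size. A similar lower number in this assay is therefore expected, with the expected step being an at least 5.0-fold lower number from compound 2 to compound 4 (0.69 log units; beyond the scatter). For compound 4 the estimate is 200 nM, with an expected range of 40 nM to 1000 nM.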

Compound 4, half-maximal inhibitory concentration: 25 nM
The estimate for compound 4 lay 8.0-fold (0.90 log units) above the measured number; measured number below the stated range.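

Within the data shown here, on the aromatic carbon of this series, the first comparison between two real numbers in this assay is a 3.8-fold lower number from compound 3 to compound 4 (0.58 log units; beyond the scatter) with ((pyridin-3-yl)carbonyl)amino in place of dimethylamino on the saturated chain carbon. The steps of an at least 40-fold lower number from compound 2 to compound 4 (1.60 log units; beyond the scatter) and an at least 4.0-fold lower number from compound 1 to compound 4 (0.60 log units; beyond the scatter) are floors only, as each starts from a limit and not from a number. So a group with no net charge can stand at this position in a compound with a real number in this assay.

No measurement shown accounts for the gain. From the compounds shown here alone, whether a carboxylic acid, a phenyl ring in place of pyridin-3-yl or a longer chain would hold this level stays open.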